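Pyridin-3-yl Exchanged for Phenyl in a Dithiocarbamate Series

A few compounds are considered here, and "the series" means these few. Any claim that something is new, unique, unknown or untested is made for them only; others in the source may bear on it.

Measured compounds in a functional assay on A-375 cells (Homo sapiens) for antiproliferative activity, read by CCK-8 assay, with a stated time of 72 h, tested at 8 uM; a higher number here means a stronger effect of the compound at the concentration tested, a lower number a weaker effect:
Compound 1 `Nc1ccccc1NC(=O)c1ccc(CSC(=S)N2CCN(c3ccccc3)CC2)cc1`: 88.6%
Compound 2 `Nc1ccccc1NC(=O)c1ccc(CSC(=S)N2CCN(Cc3cccnc3)CC2)cc1`: 89.2%

Compound 2 holds the higher of the two numbers, but its gap to compound 1 is within the scatter. Compound 3 `Nc1ccccc1NC(=O)c1ccc(CSC(=S)N2CCN(Cc3ccccc3)CC2)cc1` differs from compound 2 by phenyl in place of pyridin-3-yl on a saturated chain carbon bound to an amine nitrogen in a ring. Within the data shown here, one measured step bears on this: the earlier exchange of the aromatic group on that amine nitrogen, a number 0.6 percentage points higher from compound 1 to compound 2 (within the scatter), which stayed within the scatter. A comparable exchange of a six-membered aromatic ring is therefore expected to leave this assay essentially unchanged, with a number 1.2 percentage points lower from compound 2 to compound 3 (within the scatter) expected to fall within the scatter. Compound 3 is estimated at 88%, between 78% and 96%.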

Compound 3, a percentage reported as inhibition, at one concentration (the size of the read-out at that concentration, not a potency): 29.3%
For compound 3 the middle estimate is 58.7 percentage points above the measured one; measured number below the stated range.
By their numbers in this assay, from the lowest: compound 3; then compounds 1 and 2 (each within the scatter of the next).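

Among these compounds, on a saturated chain carbon bound to an amine nitrogen in a ring, the single exchange of pyridin-3-yl for phenyl matters in this assay, giving a number 59.9 percentage points lower from compound 2 to compound 3 (beyond the scatter), so the ring nitrogen cannot be exchanged freely here. Lengthening phenyl to benzyl on the amine nitrogen gives a number 59.3 percentage points lower from compound 1 to compound 3 (beyond the scatter), so the three groups do not act alike at this nitrogen. No available evidence accounts for this difference. Going by these compounds, whether pyridin-4-yl or a longer chain such as 2-phenylethyl would follow compound 2 or compound 3 remains open.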